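Chain length at the amine nitrogen in a small series

The compounds below may be only part of what the source reports. "The series", "measured", "known", "first", "only" and "open" are said of these compounds alone.

Two compounds of this series have numbers in an assay on CHO cells for displacement of a labelled ligand from C-X-C chemokine receptor type 3 (Homo sapiens), with a stated time of 60 min; a lower number here means a stronger inhibitor, a higher number a weaker inhibitor. Compound 1 `Cc1cc(CN(C)C(CC(=O)O)c2ccc(Cl)cc2)ccc1OCCn1c(=O)ccn(C)c1=O` gives 1300 nM in this assay. Compound 2 `CCN(Cc1ccc(OCCn2c(=O)ccn(C)c2=O)c(C)c1)C(CC(=O)O)c1ccc(Cl)cc1` gives 428 nM in this assay. Compound 2 thus stands lowest of the two numbers shown, with compound 1 the nearest, and the one measured step, a 3.0-fold lower number from compound 1 to compound 2 (0.48 log units; beyond the scatter), is the change that separates them. The step to compound 3 `CCCN(Cc1ccc(OCCn2c(=O)ccn(C)c2=O)c(C)c1)C(CC(=O)O)c1ccc(Cl)cc1` continues the same line: methyl in place of hydrogen on a saturated chain carbon, two bonds along the chain from an amine nitrogen. Cut one bond further out, the change from compound 1 to compound 2 reads methyl to ethyl and the change from compound 2 to compound 3 reads ethyl to propyl. For the measured compounds named here, only the step from compound 1 to compound 2 bears on it; that step was modest and beyond the scatter. Whether a further carbon on the chain repeats that gain cannot be read from two compounds, so a smaller step downward, or none beyond the scatter, is expected, and the estimated step is a 1.4-fold lower number from compound 2 to compound 3 (0.15 log units; within the scatter). Compound 3 is therefore expected at 300 nM, within a range from 120 nM to 900 nM.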

Compound 3, half-maximal inhibitory concentration: 123 nM
The estimate for compound 3 lay 2.4-fold (0.39 log units) above the measured number; the range from low to high includes it.
By their numbers in this assay, from the lowest: compound 3; then compound 2; then compound 1.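

Working notes: in this assay, the first added carbon did not mark the end of the gain, since a 3.5-fold lower number from compound 2 to compound 3 (0.54 log units; beyond the scatter) is a step of similar size to a 3.0-fold lower number from compound 1 to compound 2 (0.48 log units; beyond the scatter), and the expected tapering does not appear at this position. Across the methyl, ethyl and propyl groups on the amine nitrogen, the number falls at each step, and an 11-fold lower number from compound 1 to compound 3 (1.02 log units; beyond the scatter) makes the whole change large rather than modest, with no compound among the three going against this order and compound 3 lowest by steps beyond the scatter to both others. No evidence at hand bears on why the number falls along this chain.

The compounds shown end at propyl, leaving open whether butyl or a longer chain would extend the fall, hold it level or reverse it. Also open, as far as these compounds go, is whether a branched group such as isopropyl, or a chain ending in a hydroxyl group, would follow the same line at the amine nitrogen.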